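Propyl to Isopropyl on the Amide of Compound 2

The source may report more compounds than this note shows. Statements on the series, on what has been measured and on what is new or still open speak of the compounds shown alone.

This account follows the step from compound 2 `CCCC(=O)N1CCC(CN(C2Cc3cc(C#N)ccc3N(Cc3cncn3C)C2)S(=O)(=O)c2ccccn2)CC1` to compound 4 `CC(C)C(=O)N1CCC(CN(C2Cc3cc(C#N)ccc3N(Cc3cncn3C)C2)S(=O)(=O)c2ccccn2)CC1`. In an ADME assay on Caco-2 cells (Homo sapiens) for permeability, in the apical to basolateral direction (on this read-out lower numbers stand for lower permeability and higher numbers for higher permeability), compound 2 gives 0.5 10^-6 cm/s, the lowest of the three numbers measured. Its nearest neighbour is compound 1 `Cn1cncc1CN1CC(N(CC2CCN(C(=O)Nc3ccc(Br)cc3)CC2)S(=O)(=O)c2ccccn2)Cc2cc(C#N)ccc21`, which in this assay gives 0.6 10^-6 cm/s; the step of a 1.2-fold lower number from compound 1 to compound 2 (0.08 log units; within the scatter) lies within the scatter. The furthest is compound 3 `Cc1noc(C)c1CN(C1Cc2cc(C#N)ccc2N(Cc2cncn2C)C1)S(=O)(=O)c1ccccn1`, which in this assay gives 8 10^-6 cm/s; the step of a 16-fold higher number from compound 2 to compound 3 (1.20 log units; beyond the scatter) is large and beyond the scatter.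

The change to compound 4 is isopropyl in place of propyl on a carbonyl carbon, a rearrangement of the same atoms: propyl leaves and isopropyl enters on the carbonyl carbon bound to the amide-type nitrogen in a ring. Among the compounds with values here, the one measured step at that carbonyl, from compound 1 to compound 2, stayed within the scatter even though (4-bromophenyl)amino was exchanged for propyl. The large step to compound 3 concerns a different place and does not bear on this change.

Compound 4 is therefore expected to show a step of no change at the digits printed from compound 2 to compound 4 (within the scatter) that stays within the scatter. The estimate for compound 4 in this assay is 0.5 10^-6 cm/s, with a range from 0.25 10^-6 cm/s to 1 10^-6 cm/s.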

Compound 4, apparent permeability: 0.5 10^-6 cm/s
For compound 4 middle estimate and measured number coincide at the digits printed; the measured number falls inside the stated range.
By their numbers in this assay, from the lowest: compounds 2, 4 and 1 (each within the scatter of the next); then compound 3.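

In this assay, putting isopropyl in place of propyl on the carbonyl carbon gives no change at the digits printed from compound 2 to compound 4 (within the scatter) and so shows that this rearrangement of the same atoms leaves the read-out unmoved. The step of a 1.2-fold lower number from compound 1 to compound 4 (0.08 log units; within the scatter) adds a second comparison with (4-bromophenyl)amino, so all three groups shown on this carbonyl, in compounds 1, 2 and 4, now lie within the scatter of one another. The step of a 16-fold lower number from compound 3 to compound 4 (1.20 log units; beyond the scatter) shows that the large gap to the 3,5-dimethyl-1,2-oxazol-4-yl group also holds with 1-(isopropylcarbonyl)piperidin-4-yl in place, and nothing measured here gives a reason for that gap.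

From the compounds shown here alone, it remains open whether a carbonyl bearing an aminomethyl group or a longer chain such as octyl would stay within the same scatter. Also open, going by these compounds, is which part of the 1-(isopropylcarbonyl)piperidin-4-yl group goes with the large step to compound 3.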